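This account rests on a few compounds, and the source may have more. Where it says the series, first, only, none or still open, it means among the compounds named here.

Compound 1, `CCCCOCCn1c(N2CCCN(C)CC2)nc2ccccc21`, in a functional assay on ileum for inhibition of histamine H1 receptor (Cavia porcellus); a lower number here means a stronger inhibitor, a higher number a weaker inhibitor: compound 1 gives 10 nM.
Compound 2, `CN1CCN(c2nc3ccccc3n2CCOc2ccccc2)CC1`: compound 2 gives 6.9 nM.
Compound 3, `CN1CCCN(c2nc3ccccc3n2CCOc2ccccc2)CC1`: compound 3 gives 9.1 nM.

Compound 2 gives the lowest of the three numbers in this assay, but neither of the other two stands apart from it: the step of a 1.3-fold higher number from compound 2 to compound 3 (0.12 log units; within the scatter) is within the scatter, and compound 1 with 10 nM sits close to the value of compound 2 as well. The unmeasured compound 4, `CCCCCCCCCCn1c(N2CCN(C)CC2)nc2ccccc21`, differs from compound 2 in one place: octyl in place of phenoxy on a saturated chain carbon, two bonds along the chain from an aromatic nitrogen. Among the measured compounds shown here, only one measured step touches the same part of the molecule, the exchange of the group on the oxygen of the chain, a 1.1-fold lower number from compound 1 to compound 3 (0.04 log units; within the scatter), which did not move the number beyond the scatter. For the measured compounds named here, no measured step removes the oxygen or lengthens the chain to an octyl, so the account of compound 4 rests on that single step alone, and it points to little change. A modest shift toward a higher number is allowed for the unknown, but nothing in the measured pairs demands it. Compound 4 is therefore expected to give 12 nM in this assay, with a range from 3 nM to 50 nM. Against compound 2, this estimate means a step of a 1.7-fold higher number from compound 2 to compound 4 (0.24 log units; within the scatter).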

Compound 4, half-maximal inhibitory concentration: 4200 nM
Estimate against measurement, compound 4: 350-fold (2.54 log units) below, outside the stated range (above it).
By their numbers in this assay, from the lowest: compounds 2, 3 and 1 (each within the scatter of the next); then compound 4.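

In this assay, among the compounds shown here, the step of a 610-fold higher number from compound 2 to compound 4 (2.78 log units; beyond the scatter) shows that this position on the chain does not tolerate every change, which the earlier compounds gave no sign of. For the compounds shown here, the earlier exchange, a 1.1-fold lower number from compound 1 to compound 3 (0.04 log units; within the scatter), kept the oxygen and replaced only the group on it, so butyl and phenyl were not told apart there; the new step is the first in which the oxygen itself leaves. Phenoxy also takes its aromatic ring and its hydrogen-bond acceptor with it, and octyl brings neither, so this single step carries the loss of the oxygen and the loss of the ring together and cannot separate them.

The compounds shown leave open which of these matters, and whether the length of the chain plays a part: a phenylbutyl group would keep the ring without the oxygen, while a butoxy or octyloxy group on the compound with 4-methylpiperazin-1-yl would keep the oxygen without the ring. Nothing given here accounts for the size of this step.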